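A few compounds are considered here, and "the series" means these few. Any claim that something is new, unique, unknown or untested is made for them only; others in the source may bear on it.

Measured in an ADME assay on BE(2)-C cells (Homo sapiens) for cytotoxicity, read by MTT assay, with a stated time of 20 h; a lower number here means that less compound is tolerated, a higher number that more compound is tolerated:
Compound 1 `O=C(NCc1ccncc1)C1CCN(C(=O)c2cc3ccccc3n2Cc2ccc(Cl)cc2)CC1` gives > 100000 nM (a limit)
Compound 2 `CN1CCN(C(=O)C2CCN(C(=O)c3cc4ccccc4n3Cc3ccc(Cl)cc3)CC2)CC1` gives 75600 nM
Compound 3 `CN(Cc1ccccc1)C(=O)C1CCN(C(=O)c2cc3ccccc3n2Cc2ccc(C#N)cc2)CC1` gives > 100000 nM (a limit)

Compound 3 therefore has no number of its own in this assay, only a limit. The same limit holds for compound 1, so compound 2 alone carries a number, and the picture is the limit of > 100000 nM in this assay, at which 2 of the 3 values shown sit.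

Compound 4 `CN(Cc1ccccc1)C(=O)C1CCN(C(=O)c2cc3ccccc3n2Cc2ccccc2)CC1` follows from compound 3 by hydrogen in place of cyano on an aromatic carbon (hydrogen in place of cyano on an aromatic carbon, so 4-cyanobenzyl becomes benzyl). Within the data shown here, the only measured step is an at least 1.3-fold lower number from compound 1 to compound 2 (0.12 log units; that floor lies within the scatter). Among the measured compounds shown here, it swaps a different group, on a carbonyl carbon, so it bears only loosely on this change, and no measured step touches the cyano position.

With compound 3 at > 100000 nM as the nearest guide, no step beyond the scatter is expected, in either direction. The step expected from this estimate is an at least 1.0-fold lower number from compound 3 to compound 4 (0.02 log units; that floor lies within the scatter) (and it may well end at the same limit). The estimate for compound 4 is 95000 nM (expected range 45000 nM to 200000 nM).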

Compound 4, half-maximal cytotoxic concentration: 64800 nM
Compound 4: the middle estimate sits 1.5-fold (0.17 log units) above what was measured; low and high end bracket the measured number.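

In this assay, replacing the cyano group of the 4-cyanobenzyl group with hydrogen gives an at least 1.5-fold lower number from compound 3 to compound 4 (0.18 log units; that floor lies within the scatter). The value of compound 3, > 100000 nM, is a limit. Among these compounds, the earlier compounds offered no measured step at this position, and compound 4 supplies one, though it shows only that the change from 4-cyanobenzyl to benzyl has a floor within the scatter, and limits still mark much of the set: the limit of > 100000 nM in this assay, at which 2 of the 4 values shown sit.

From the compounds shown here alone, what an amine or a carboxylic acid at this place on the aromatic ring would do remains open. Also open is how the 4-chlorobenzyl group of compound 1 and compound 2 would compare with benzyl or 4-cyanobenzyl on the amide shared by compound 3 and compound 4, since no pair shown differs in that one place.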